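The compounds below may be only part of what the source reports. "The series", "measured", "known", "first", "only" and "open" are said of these compounds alone.

Compound 1 `CN1C(=O)C(c2cccc(Cl)c2)N(C)c2nc(Nc3ccc(S(N)(=O)=O)cc3)ncc21`: 989 nM
Compound 2 `COc1ccccc1C1C(=O)N(C)c2cnc(Nc3ccc(S(N)(=O)=O)cc3)nc2N1C`: 251 nM

In an assay on Sf9 cells for inhibition of serine/threonine-protein kinase 4 (Homo sapiens), read by luminescence and ADP-Glo, with a stated time of 1 h, in the presence of a further agent that is not named here (on this read-out lower numbers stand for stronger inhibition and higher numbers for weaker inhibition), compound 2 has the lower of the two numbers shown, its only neighbour being compound 1 at 989 nM. Within the data shown here, the one measured step, a 3.9-fold lower number from compound 1 to compound 2 (0.60 log units; beyond the scatter), swapped one aryl ring for another on the same saturated ring carbon. Compound 3 `Cc1ccc(F)cc1C1C(=O)N(C)c2cnc(Nc3ccc(S(N)(=O)=O)cc3)nc2N1C` makes a further swap at that carbon: 5-fluoro-2-methylphenyl in place of 2-methoxyphenyl on a saturated ring carbon. Among the measured compounds shown here, that step has no direct measured counterpart, so its direction is uncertain; an expected step of a 2.0-fold higher number from compound 2 to compound 3 (0.30 log units; within the scatter) seems reasonable. Compound 3 is therefore estimated at 500 nM, within 150 nM to 1600 nM.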

Compound 3, half-maximal inhibitory concentration: 168 nM
Compound 3: the middle estimate sits 3.0-fold (0.47 log units) above what was measured, within the range that was stated.
By their numbers in this assay, from the lowest: compounds 3 and 2 (each within the scatter of the next); then compound 1.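

In this assay, the change shows that this saturated ring carbon tolerates losing the hydrogen-bond acceptor of 2-methoxyphenyl: a 1.5-fold lower number from compound 2 to compound 3 (0.17 log units; within the scatter). Both rings with a group in the 2-position, 2-methoxyphenyl and 5-fluoro-2-methylphenyl, give lower numbers than 3-chlorophenyl, and the new compound confirms this with a 5.9-fold lower number from compound 1 to compound 3 (0.77 log units; beyond the scatter). Nothing available here explains either step. Three aryl rings cannot show which ring feature matters, or whether plain phenyl would give a similar number. From the compounds shown here alone, how an amine or a carboxylic acid on this ring would behave also remains open.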